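Aryloxypyrazole oxime ethers: antiproliferative screen, moving to compound 4

This account rests on a few compounds, and the source may have more. Where it says the series, first, only, none or still open, it means among the compounds named here.

Measured so far in a functional assay on MCF7 cells (Homo sapiens) for antiproliferative activity, tested at 1 uM; a higher number here means more inhibition at the concentration tested (going by the name of the read-out), a lower number less inhibition:
compound 1 `Cc1ccc(CO/N=C/c2c(C)nn(C)c2Oc2ccc(Cl)cc2)cc1` gives 30.7%
compound 2 `Cc1nn(C)c(Oc2ccccc2)c1/C=N/OCc1ccc(C(F)(F)F)cc1` gives 30.5%
compound 3 `Cc1nn(C)c(Oc2ccccc2)c1/C=N/OCc1ccc([N+](=O)[O-])cc1` gives 24%

Compound 3 holds the lowest of the three numbers, but its gaps to compound 2 and to compound 1 both lie within the scatter, so no ordering among them can be read. Among the measured compounds shown here, the one single-point step, a number 6.5 percentage points lower from compound 2 to compound 3 (within the scatter), is itself within the scatter.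

Compound 4 `Cc1ccc(CO/N=C/c2c(C)nn(C)c2Oc2ccccc2)cc1` arises from compound 3 by methyl in place of nitro on an aromatic carbon. For the measured compounds named here, compound 1 already carries the 4-methylphenyl and gives 30.7%, though it differs from compound 4 elsewhere, so no step to compound 4 is defined for it. Going by the values given here, with the only relevant step within the scatter, no movement beyond the scatter is expected in this assay. Compound 4 is estimated at 29%, range 19% to 39%. The expected step is a number 5 percentage points higher from compound 3 to compound 4 (within the scatter).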

Compound 4, a percentage reported as inhibition, at one concentration (the size of the read-out at that concentration, not a potency): 38.2%
Estimate against measurement, compound 4: 9.2 percentage points below; the range from low to high includes it.
By their numbers in this assay, from the lowest: compounds 3, 2, 1 and 4 (each within the scatter of the next, the first and the last beyond it).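

In this assay, among the compounds shown here, methyl in place of nitro gives the first step beyond the scatter (a number 14.2 percentage points higher from compound 3 to compound 4 (beyond the scatter)), so the group on this para position of the six-membered aromatic ring can shift the read-out. Methyl in place of trifluoromethyl (a number 7.7 percentage points higher from compound 2 to compound 4 (within the scatter)) and hydrogen in place of chloro (a number 7.5 percentage points higher from compound 1 to compound 4 (within the scatter)) stay within the scatter, so only the nitro to methyl pair is separated. No evidence here bears on the origin of this step.

Going by these compounds, whether an amine, a carboxylic acid or a longer chain at this position would fall nearer to methyl or to nitro remains open. Also open, on these data alone, is whether the nitro to methyl step would carry over to the core of compound 1, with its chloro.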